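Two Aryl Groups on a Shared Core, One Swap Ahead

A few compounds are considered here, and "the series" means these few. Any claim that something is new, unique, unknown or untested is made for them only; others in the source may bear on it.

Compound 1 `COc1ccccc1-c1cnc(NC(=O)c2ccc(F)cc2)n1C` and compound 2 `COc1ccc(-c2noc(NC(=O)c3ccc(F)cc3)c2C)cc1` were both examined in a toxicity assay on THP-1 cells (Homo sapiens) for inhibition; on this read-out lower numbers stand for higher toxicity in this test and higher numbers for lower toxicity in this test. For compound 1 the read-out is only a limit of the assay, > 100000 nM. For compound 2 the read-out is likewise only a limit of the assay, > 100000 nM. Compound 1 thus stands where this test stops reporting numbers, and the other value shown stands there too: the limit of > 100000 nM in this assay, at which 2 of the 2 values shown sit. Within the data shown here, no step between two measured compounds can be read off here, so the size of any step can only be expected. Compound 3 `Cn1c(-c2cccc(F)c2)cnc1NC(=O)c1ccc(F)cc1` differs from compound 1 in one place: 3-fluorophenyl in place of 2-methoxyphenyl on an aromatic carbon. With both known values sitting at the limit, the expected step in this assay is none beyond the usual scatter, with the direction open. Compound 3 is therefore expected near 100000 nM, in a range from 50000 nM to 300000 nM. This corresponds to an expected step of a number no higher from compound 1 to compound 3 (the limit leaves the size open) that stays within the scatter.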

Compound 3, half-maximal cytotoxic concentration: 58000 nM
Beside the measured number, compound 3's estimate is 1.7-fold (0.24 log units) above it, and the stated range covers the measured number.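

In this assay, replacing 2-methoxyphenyl with 3-fluorophenyl on this aromatic carbon gives an at least 1.7-fold lower number from compound 1 to compound 3 (0.23 log units; that floor lies within the scatter). This shows that a change at this position alone can bring the read-out to a reported number, although the printed floor does not establish a step beyond the usual scatter, and the true size of the step cannot be read. Compound 3 is the only one of the three with a reported number, and the others stand at the limit of the test: the limit of > 100000 nM in this assay, at which 2 of the 3 values shown sit.

The compounds shown leave open whether the read-out follows the fluorine, the loss of the methoxy group or the place of the substituent on the phenyl ring, all of which change together in this single step. They also leave open how a phenyl ring bearing an amine or a carboxylic acid would read in this assay.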